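A few compounds are considered here, and "the series" means these few. Any claim that something is new, unique, unknown or untested is made for them only; others in the source may bear on it.

Measured so far:
compound 1 `O=C(Nc1cc(F)cc(F)c1)c1cc(=O)[nH]c2cc(C(F)(F)F)ccc12` — 14200 nM
compound 2 `CC(=O)c1ccc(-c2ccc3c(C(=O)Nc4cccc(F)c4)cc(=O)[nH]c3c2)cc1` — > 20000 nM (a limit of the assay, not a number)

In a functional assay on KYSE-70 cells for antiproliferative activity against KYSE-70 cell line (Homo sapiens), read by MTT assay, with a stated time of 72 h (on this read-out lower numbers stand for stronger inhibition and higher numbers for weaker inhibition), compound 1 gives 14200 nM. For compound 2 the read-out in this assay is a limit only, > 20000 nM, so compound 2 stands at the limit of > 20000 nM in this assay, at which 1 of the 2 values shown sits, and its true value is not known. Compound 3 `O=C(Nc1cccc(F)c1)c1cc(=O)[nH]c2cc(-c3cccnc3F)ccc12` is the next compound for this assay. Compared with compound 2 it carries 2-fluoropyridin-3-yl in place of 4-acetylphenyl on an aromatic carbon. Among the compounds with values here, no step between two measured compounds bears on this change, and the starting point is a limit, so the size of the step cannot be anchored. The expectation in this assay is a step of about the usual scatter, with a move toward measurable weak inhibition, in the region where compound 1 sits with 14200 nM, as the likelier direction. The expected step is an at least 1.3-fold lower number from compound 2 to compound 3 (0.12 log units; that floor lies within the scatter). Compound 3 is estimated at 15000 nM, with a range of 4000 nM to 50000 nM, and a sizeable chance that only a limit is reported.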

Compound 3, half-maximal inhibitory concentration: > 20000 nM
Compound 3 was reported as a limit; the forecaster's own chance of this, stated with the estimate: 45%; at least 1.3-fold (0.12 log units) between middle value and limit.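

Compound 2 and compound 3 are both reported only as limits, so no step can be read between them: the limit of > 20000 nM in this assay, at which 2 of the 3 values shown sit.

Still open, as far as these compounds go, is whether 2-fluoropyridin-3-yl in place of 4-acetylphenyl changes inhibition at all in this assay, and how far the true values of compound 2 and compound 3 lie apart.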